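A Methoxy Swap on a Weak Growth Inhibitor

The compounds below may be only part of what the source reports. "The series", "measured", "known", "first", "only" and "open" are said of these compounds alone.

In a functional assay on DU-145 cells (Homo sapiens) for inhibition, read by trypan blue exclusion, with a stated time of 96 h (on this read-out lower numbers stand for stronger inhibition of growth and higher numbers for weaker inhibition of growth), compound 1 `Cc1ccc(S/C(=C/c2c(O)cc(O)cc2O)C(=O)c2ccc(Cl)cc2)cc1` reads > 100000 nM as a limit, not a number. Going by the values given here, compound 2 `Cc1ccc(S/C(=C/c2cc(C)cc(C)c2)C(=O)c2ccc(Cl)cc2)cc1` gives 50000 nM in this assay and so holds the only true number so far. Compound 3 `COc1ccccc1/C=C(/Sc1ccc(C)cc1)C(=O)c1ccc(Cl)cc1` carries 2-methoxyphenyl in place of 3,5-dimethylphenyl on a double-bonded chain carbon bound to a double-bonded chain carbon and the rest of the structure stays the same. Among the compounds with values here, only one measured step bears on this place: an at least 2.0-fold lower number from compound 1 to compound 2 (0.30 log units; that floor lies within the scatter) and that is too little to set a direction, so no step beyond the scatter is expected in this assay from the new group. The estimated step is a 1.7-fold lower number from compound 2 to compound 3 (0.22 log units; within the scatter) and it stays within the scatter. Compound 3 is expected near 30000 nM with an estimated range from 6000 nM to 100000 nM for its growth inhibition.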

Compound 3, concentration for 50% growth inhibition: 25000 nM
Compound 3: middle estimate off by 1.2-fold (0.08 log units), on the high side; the measured number falls inside the stated range.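

At this place on a double-bonded chain carbon bound to a double-bonded chain carbon, 2-methoxyphenyl and 3,5-dimethylphenyl cannot be told apart, with a 2.0-fold lower number from compound 2 to compound 3 (0.30 log units; within the scatter). The shown change that clears the scatter is the one away from 2,4,6-trihydroxyphenyl, with an at least 4.0-fold lower number from compound 1 to compound 3 (0.60 log units; beyond the scatter), so the group at this place can shift the read-out. That step is only a floor, since compound 1 is held at a limit and not a number: the limit of > 100000 nM in this assay, at which 1 of the 3 values shown sits.

Still open, on these data alone, is whether any group at this place can bring growth inhibition much stronger than the values of compound 2 and compound 3, which lie within the scatter of each other. As far as these compounds go, how a phenyl group carrying an amine or a carboxylic acid would read here also remains unknown.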